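Swapping Methoxy for Chloro on an Aromatic Carbon

This account rests on a few compounds, and the source may have more. Where it says the series, first, only, none or still open, it means among the compounds named here.

In a functional assay on A549/CDDP cells (Homo sapiens) for antiproliferative activity, read by MTT assay, with a stated time of 72 h (on this read-out lower numbers stand for stronger inhibition and higher numbers for weaker inhibition), compound 1 `Cc1nc(C)c(/C=C/C(=O)/C=C/c2cccc(O)c2)nc1C` gives 3700 nM and compound 2 `COc1ccc(/C=C/C(=O)/C=C/c2nc(C)c(C)nc2C)cc1` gives 3610 nM. These two numbers lie within the usual scatter of repeated measurements, so compound 2 stands level with compound 1 and neither can be ranked over the other. The next structure, compound 3 `Cc1nc(C)c(/C=C/C(=O)/C=C/c2ccc(Cl)cc2)nc1C`, shares its core with compound 2 and differs from it in one place: chloro in place of methoxy on an aromatic carbon. For the measured compounds named here, no measured pair here shows what a single change of this kind does, so any forecast remains loose. Going by the values given here, the only guide is that compound 1, at 3700 nM, and compound 2, at 3610 nM, give such similar numbers although their structures differ. On that basis, no shift beyond the scatter is expected in this assay, and the estimated change is a 1.2-fold lower number from compound 2 to compound 3 (0.08 log units; within the scatter). For compound 3 the estimated value is 3000 nM, with an expected range from 1200 nM to 7000 nM.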

Compound 3, half-maximal inhibitory concentration: 7490 nM
The estimate for compound 3 lay 2.5-fold (0.40 log units) below the measured number; measured number above the stated range.
By their numbers in this assay, from the lowest: compounds 2 and 1 (each within the scatter of the next); then compound 3.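

In this assay, chloro in place of methoxy on an aromatic carbon, para to a large group, gives a 2.1-fold higher number from compound 2 to compound 3 (0.32 log units; beyond the scatter), the first difference here that lies beyond the scatter. This shows that the group at this position can change the result, although the step is modest and runs towards weaker inhibition. The step with 4-chlorophenyl in place of 3-hydroxyphenyl gives a 2.0-fold higher number from compound 1 to compound 3 (0.31 log units; beyond the scatter), so compound 3 also stands apart from compound 1, but no available measurement explains either shift.

The compounds shown leave open whether methoxy improves the result or chloro worsens it, since only a compound with plain hydrogen on this aromatic carbon could separate those two readings. They also leave open how an amine or a carboxylic acid at the same position would compare, including whether either would move the number beyond the scatter and in which direction.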